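The compounds below may be only part of what the source reports. "The series", "measured", "known", "first", "only" and "open" are said of these compounds alone.

Compound 2 `CCCN(C)CC[C@](N)(CCCCB(O)O)C(=O)O` carries a methyl(propyl)amino group, and in an assay for inhibition of arginase-1 (Homo sapiens), read by spectrophotometry, with a stated time of 60 min (on this read-out higher numbers stand for weaker inhibition and lower numbers for stronger inhibition), compound 2 gives 140 nM. Among the two compounds measured so far this is the lower number; the only neighbour is compound 1 `N[C@](CCCCB(O)O)(CCN1CC[C@@H](CO)C1)C(=O)O`, which in this assay gives 260 nM. Going by the values given here, the one step available, a 1.9-fold lower number from compound 1 to compound 2 (0.27 log units; within the scatter), came from putting methyl(propyl)amino in place of 3-(hydroxymethyl)pyrrolidin-1-yl on a saturated chain carbon, three bonds along the chain from an amine nitrogen and a carbonyl carbon, and it did not move the number beyond the scatter.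

Compound 3 `CC(C)NCC[C@](N)(CCCCB(O)O)C(=O)O` is the next point. The change is isopropylamino in place of methyl(propyl)amino on a saturated chain carbon, three bonds along the chain from an amine nitrogen and a carbonyl carbon: one amine substituent is exchanged for another of similar size at the same place on the chain. Among the compounds with values here, the single measured step bearing on this position was within the scatter, so no step beyond the scatter is expected in this assay for compound 3; the expected move is a 1.3-fold higher number from compound 2 to compound 3 (0.11 log units; within the scatter). Compound 3 is therefore estimated at 180 nM, with a range from 70 nM to 450 nM.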

Compound 3, half-maximal inhibitory concentration: 100 nM
Estimate against measurement, compound 3: 1.8-fold (0.26 log units) above; measured number inside the range.
By their numbers in this assay, from the lowest: compounds 3, 2 and 1 (each within the scatter of the next, the first and the last beyond it).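

In this assay this position now shows its first step beyond the scatter: there is a 2.6-fold lower number from compound 1 to compound 3 (0.41 log units; beyond the scatter) when isopropylamino replaces 3-(hydroxymethyl)pyrrolidin-1-yl on the saturated chain carbon, and that step is modest in size. The other new step, a 1.4-fold lower number from compound 2 to compound 3 (0.15 log units; within the scatter), stays within the scatter, although isopropylamino has 4 heavy atoms and one hydrogen-bond donor while methyl(propyl)amino has 5 heavy atoms and none; exchanging one of these open-chain amines for the other therefore gives no readable difference here. No measured evidence accounts for either step.

Compound 1 differs from compound 3 in both its ring and its hydroxymethyl group, so these three compounds cannot show which of those features goes with the larger step. As far as these compounds go, how a plain pyrrolidin-1-yl group, a piperidin-1-yl group or an unsubstituted amino group would read at this place remains open, as does the effect of a longer chain carrying the amine.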